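This account rests on a few compounds, and the source may have more. Where it says the series, first, only, none or still open, it means among the compounds named here.

Working notes on the series in a functional assay on A549 cells (Homo sapiens) for inhibition, read by MTT assay, with a stated time of 24 h; on this read-out lower numbers stand for stronger inhibition of growth and higher numbers for weaker inhibition of growth. Compound 1 `COc1ccc2c(c1)c(-c1nc3ccccc3n1C(=O)c1ccccc1OC)cn2C` gives 11900 nM, compound 2 `COc1ccc(C(=O)n2c(-c3cn(C)c4ccc(OC)cc34)nc3ccccc32)cc1` gives 4900 nM, and compound 3 `COc1ccc2c(c1)c(-c1nc3ccccc3n1C(=O)c1ccc(OC)c(OC)c1)cn2C` gives 2700 nM. Compound 3 cannot be separated from compound 2, as the measured change is a 1.8-fold lower number from compound 2 to compound 3 (0.26 log units; within the scatter). Both stand clear of compound 1, with a 2.4-fold lower number from compound 1 to compound 2 (0.39 log units; beyond the scatter) and a 4.4-fold lower number from compound 1 to compound 3 (0.64 log units; beyond the scatter).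

Compound 4 `COc1ccc(C(=O)n2c(-c3cn(C)c4ccc(Br)cc34)nc3ccccc32)cc1OC` differs from compound 3 by bromo in place of methoxy on an aromatic carbon. All three measured steps alter the aryl group on the carbonyl carbon, and none touches the place changed here. They therefore bear on this step only indirectly, by showing that changes elsewhere in the series have so far been modest. No step beyond the scatter is expected in this assay, and the data give no direction, so the range is kept wide. The step expected is a 1.1-fold higher number from compound 3 to compound 4 (0.05 log units; within the scatter). For compound 4 the estimated value is 3000 nM, with an expected range from 1000 nM to 9000 nM.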

Compound 4, concentration for 50% growth inhibition: 3400 nM
The estimate for compound 4 lay 1.1-fold (0.05 log units) below the measured number, within the range that was stated.
By their numbers in this assay, from the lowest: compounds 3, 4 and 2 (each within the scatter of the next); then compound 1.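

Among these compounds, the earlier steps all altered the aryl group on the carbonyl carbon, whereas this is the first reading at the aromatic carbon in the fused system of two rings: in this assay, bromo in place of methoxy gives a 1.3-fold higher number from compound 3 to compound 4 (0.10 log units; within the scatter). On this single pair, the methoxy at this place is not needed to keep the number of compound 3, since bromo cannot be separated from it. Nothing measured on hand accounts for this result.

On these data alone, one pair gives no direction, so it remains open whether an amine or a carboxylic acid at this place would move the number beyond the scatter. Also open, as far as these compounds go, is whether the same swap would read alike with another aryl group on the carbonyl carbon, such as the 2-methoxyphenyl of compound 1.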